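A few compounds are considered here, and "the series" means these few. Any claim that something is new, unique, unknown or untested is made for them only; others in the source may bear on it.

Measured compounds:
- compound 1 `Nc1scc(CN2CCN(c3ccc([N+](=O)[O-])cc3)CC2)c1C(=O)c1ccc(Cl)cc1`: in a functional assay on CHO cells with adenosine receptor A1 (Homo sapiens) as the target, read by cAMP accumulation and immunoassay, with a stated time of 6 min, tested at 0.01 uM (on this read-out higher numbers stand for a weaker effect at the one concentration tested and lower numbers for a stronger effect), compound 1 gives -12%
- compound 2 `Nc1scc(CN2CCN(c3ccccc3F)CC2)c1C(=O)c1ccc(Cl)cc1`: in this assay compound 2 gives 2.1%
- compound 3 `Nc1scc(CN2CCN(c3ccc(F)c(F)c3)CC2)c1C(=O)c1ccc(Cl)cc1`: in this assay compound 3 gives -3.2%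

All three compounds share one core and differ only in the aryl group on the amine nitrogen of the ring. The numbers sit close together: the step of a number 14.1 percentage points higher from compound 1 to compound 2 (beyond the scatter) is the only one beyond the scatter, while a number 8.8 percentage points higher from compound 1 to compound 3 (within the scatter) and a number 5.3 percentage points lower from compound 2 to compound 3 (within the scatter) are within it. Compound 3 thus stands second highest of the three, and its gap to compound 2 on one side and to compound 1 on the other side is within the scatter, so no order among them can be claimed.

Compound 4 `Nc1scc(CN2CCN(c3cc(F)cc(F)c3)CC2)c1C(=O)c1ccc(Cl)cc1` is the next step. It differs from compound 3 by 3,5-difluorophenyl in place of 3,4-difluorophenyl on an amine nitrogen in a ring. For the measured compounds named here, no measured step exchanges one fluorine pattern for another except a number 5.3 percentage points lower from compound 2 to compound 3 (within the scatter), which was within the scatter, so a move of the same fluorines around the ring is expected to change little. The expected step in this assay is a number 1.2 percentage points higher from compound 3 to compound 4 (within the scatter), within the scatter. Compound 4 is therefore estimated at -2%, with a range from -14% to 10%.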

Compound 4, a percentage reported as activity, at one concentration (the size of the read-out at that concentration, not a potency): -13%
For compound 4 the middle estimate is 11 percentage points above the measured one; measured number inside the range.
By their numbers in this assay, from the lowest: compounds 4, 1, 3 and 2 (each within the scatter of the next, the first and the last beyond it).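

In this assay, moving the two fluorines around the phenyl ring, with the atoms unchanged, gives a number 9.8 percentage points lower from compound 3 to compound 4 (within the scatter), so this rearrangement does not separate the two groups. The 2-fluorophenyl group now differs beyond the scatter from a second aryl group, with a number 15.1 percentage points lower from compound 2 to compound 4 (beyond the scatter), while a number 1 percentage points lower from compound 1 to compound 4 (within the scatter) leaves 3,5-difluorophenyl and 4-nitrophenyl indistinguishable on this read-out. Nothing available explains these differences.

On these data alone, all four compounds carry a substituted phenyl group on the ring nitrogen, so it remains open how a methoxy group on that phenyl, or a benzyl group in its place, would read. Each number also comes from a single concentration, so it tells only how strong or weak the effect is at that concentration.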